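This account rests on a few compounds, and the source may have more. Where it says the series, first, only, none or still open, it means among the compounds named here.

Three compounds with a shared core have numbers in an ADME assay on the whole organism for cytotoxicity, with Artemia salina as the target, with a stated time of 24 h; on this read-out higher numbers stand for an effect only at larger amounts of compound and lower numbers for an effect already at smaller amounts: compound 1 `Cc1ccc(S(=O)(=O)NC(=O)Nc2ccccc2C(=O)/C=C/c2ccc(N(C)C)cc2)cc1` gives 38.1 ug/mL, compound 2 `COc1cccc(/C=C/C(=O)c2ccccc2NC(=O)NS(=O)(=O)c2ccc(C)cc2)c1` gives 23.2 ug/mL, and compound 3 `COc1ccc(/C=C/C(=O)c2ccccc2NC(=O)NS(=O)(=O)c2ccc(C)cc2)cc1OC` gives 12.9 ug/mL. Compound 3 has the lowest of these numbers, though its lead is clear on only one side, as a 3.0-fold lower number from compound 1 to compound 3 (0.47 log units; beyond the scatter) and a 1.8-fold lower number from compound 2 to compound 3 (0.25 log units; within the scatter) show.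

Compound 4 `Cc1ccc(S(=O)(=O)NC(=O)Nc2ccccc2C(=O)/C=C/c2ccc(O)cc2)cc1` has not yet been measured. It carries 4-hydroxyphenyl in place of 3,4-dimethoxyphenyl on a double-bonded chain carbon bound to a double-bonded chain carbon. Within the data shown here, no measured compound has this group, so the evidence is indirect. The closest guide is the addition of one methoxy, a 1.8-fold lower number from compound 2 to compound 3 (0.25 log units; within the scatter). Changing the whole group gave a 1.6-fold lower number from compound 1 to compound 2 (0.22 log units; within the scatter) and, at most, the modest 3.0-fold lower number from compound 1 to compound 3 (0.47 log units; beyond the scatter). These steps suggest a small move towards a higher number in this assay, probably within the scatter. The expected step is a 1.6-fold higher number from compound 3 to compound 4 (0.19 log units; within the scatter). For compound 4 the estimated value is 20 ug/mL, with an expected range from 9 ug/mL to 45 ug/mL.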

Compound 4, concentration for half-maximal effect: 24.3 ug/mL
For compound 4 the middle estimate is 1.2-fold (0.08 log units) below the measured one; the measured number falls inside the stated range.
By their numbers in this assay, from the lowest: compounds 3, 2, 4 and 1 (each within the scatter of the next, the first and the last beyond it).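

In this assay compound 4 puts 4-hydroxyphenyl on a double-bonded chain carbon bound to a double-bonded chain carbon, and unlike 3,4-dimethoxyphenyl this group has a hydrogen-bond donor. Even so, every new step stays within the scatter (a 1.9-fold higher number from compound 3 to compound 4 (0.28 log units; within the scatter)), (a 1.0-fold higher number from compound 2 to compound 4 (0.02 log units; within the scatter)) and (a 1.6-fold lower number from compound 1 to compound 4 (0.20 log units; within the scatter)), so this swap, to a group with fewer heavy atoms, cannot be told apart from repeat-measurement noise, and compound 4 adds no clear ordering to the series. Nothing available gives a measured reason for these numbers.

Going by these compounds, it remains open whether a carboxylic acid, a primary amine or a longer chain at this place would give a step beyond the scatter. One read-out also cannot show how these compounds would behave in any other test.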